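A few compounds are considered here, and "the series" means these few. Any claim that something is new, unique, unknown or untested is made for them only; others in the source may bear on it.

Measured compounds:
- compound 1, `CCN1CCN(c2cc(C)c3cc(NC(=O)c4ccccc4C)ccc3n2)CC1`, 10900 nM
- compound 2, `Cc1cc(NCCN2CCN(C)CC2)nc2ccc(NC(=O)c3ccc(Cl)c(Cl)c3)cc12`, 1700 nM

In a functional assay on MCF7 cells (Homo sapiens) for antiproliferative activity, read by MTT assay, with a stated time of 72 h (on this read-out lower numbers stand for stronger inhibition and higher numbers for weaker inhibition), compound 2 gives the lower of the two numbers, and compound 1 sits clearly apart from it, beyond the usual scatter. Compound 3, `CCN1CCN(c2cc(C)c3cc(NC(=O)c4ccc(Cl)c(Cl)c4)ccc3n2)CC1`, has not been measured. It carries 4-ethylpiperazin-1-yl in place of (2-(4-methylpiperazin-1-yl)ethyl)amino on an aromatic carbon. The same 4-ethylpiperazin-1-yl group is present in compound 1, whose 10900 nM is the weaker of the two, so a modest move toward a higher number is expected, though the amide portion of compound 3 matches compound 2. For compound 3 the expected step is a 2.4-fold higher number from compound 2 to compound 3 (0.37 log units; beyond the scatter), giving an estimate of 4000 nM with a range from 1200 nM to 14000 nM.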

Compound 3, half-maximal inhibitory concentration in the MCF7 assay: 1380 nM
For compound 3 the middle estimate is 2.9-fold (0.46 log units) above the measured one; the measured number falls inside the stated range.
By their numbers in the MCF7 assay, from the lowest: compounds 3 and 2 (each within the scatter of the next); then compound 1.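

In the MCF7 assay, the swap of side chain gives a 1.2-fold lower number from compound 2 to compound 3 (0.09 log units; within the scatter), so 4-ethylpiperazin-1-yl and (2-(4-methylpiperazin-1-yl)ethyl)amino cannot be told apart on this read-out. With the 4-ethylpiperazin-1-yl group held fixed, the MCF7 assay shows a 7.9-fold lower number from compound 1 to compound 3 (0.90 log units; beyond the scatter), which isolates the gain from 3,4-dichlorophenyl in place of 2-methylphenyl. In a physicochemical assay for solubility (on this read-out lower numbers stand for lower solubility and higher numbers for higher solubility), compound 2 gives 106 ug/mL and compound 3 gives 11.3 ug/mL, so the side chain matters for solubility: the measured solubility of compound 2, 106 ug/mL, and of compound 3, 11.3 ug/mL, a 9.4-fold lower number (0.97 log units; beyond the scatter)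

From the compounds shown here alone, whether a morpholine ring or an open-chain dimethylamino group at this position would match these results in both assays remains open.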